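Swapping the aryl group on an allyl-bearing core

The source may report more compounds than this note shows. Statements on the series, on what has been measured and on what is new or still open speak of the compounds shown alone.

Compound 1 `C=CCn1c(=O)/c(=C\c2cccc(Cl)c2Cl)[nH]c(=O)/c1=C\c1ccccc1OC`: 500 nM
Compound 2 `C=CCn1c(=O)/c(=C\c2ccccc2OC)[nH]c(=O)/c1=C\c1ccccc1OC`: 5100 nM
Compound 3 `COc1ccccc1/C=c1/[nH]c(=O)/c(=C\c2ccccc2OC)[nH]c1=O`: "not active" (no number reported)

In a functional assay on U-937 cells (Homo sapiens) for cytotoxicity, read by CCK-8 assay, with a stated time of 72 h (on this read-out lower numbers stand for stronger inhibition and higher numbers for weaker inhibition), compound 2 gives 5100 nM, the highest number among the two compounds with a reported value; its nearest neighbour is compound 1, and the step of a 10-fold higher number from compound 1 to compound 2 (1.01 log units; beyond the scatter) separates them. Compound 3 is reported only as "not active" (no number reported), without a number.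

Compound 4 `C=CCn1c(=O)/c(=C\c2cccc(C)c2)[nH]c(=O)/c1=C\c1ccccc1OC` is not yet measured. It differs from compound 2 by 3-methylphenyl in place of 2-methoxyphenyl on a double-bonded chain carbon bound to an aromatic carbon. Among the measured compounds shown here, the only measured step at the same place is a 10-fold higher number from compound 1 to compound 2 (1.01 log units; beyond the scatter), which shows that the group on that double-bonded chain carbon can move the result strongly. For the measured compounds named here, no measured pair, however, involves 3-methylphenyl, so the direction for compound 4 cannot be read from a matching step. Taking compound 2 as the starting point and allowing for a change of similar reach as the one step shown, compound 4 is expected to give about 2500 nM in this assay, within a range from 700 nM to 9000 nM, an expected step of a 2.0-fold lower number from compound 2 to compound 4 (0.31 log units; beyond the scatter).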

Compound 4, half-maximal inhibitory concentration: 5100 nM
The estimate for compound 4 lay 2.0-fold (0.31 log units) below the measured number; the measured number falls inside the stated range.
By their numbers in this assay, from the lowest: compound 1; then compounds 2 and 4 (each within the scatter of the next).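

In this assay the exchange of the two aryl groups gives no change at the digits printed from compound 2 to compound 4 (within the scatter), so on the double-bonded chain carbon bound to an aromatic carbon, 3-methylphenyl and 2-methoxyphenyl cannot be told apart, although only 2-methoxyphenyl counts a hydrogen-bond acceptor. The comparison with the dichlorinated compound gives a 10-fold higher number from compound 1 to compound 4 (1.01 log units; beyond the scatter), which matches the step already seen for compound 2, so 2,3-dichlorophenyl now stands apart from two different aryl groups at this place rather than from one. Nothing available gives a reason for this difference.

On these data alone, it remains open whether a single chlorine, as in 3-chlorophenyl or 2-chlorophenyl, would keep the lower number of compound 1 or whether both chlorines are needed. Also open, as far as these compounds go, is how an amine or a carboxylic acid on this phenyl ring would read out.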